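The source may hold more compounds than are shown below. What is called first, only, known or untested is meant among the compounds shown, and "the series" means these compounds.

Measured so far:
Compound 1, `C1=NCC(CC2=Cc3ccccc3CC2)N1`: in a functional assay for binding affinity to Norepinephrine transporter (Rattus norvegicus), read by radioligand binding, in the presence of a further agent that is not named here (on this read-out higher numbers stand for weaker inhibition and lower numbers for stronger inhibition), compound 1 gives 50.1 nM.
Compound 2, `Fc1ccc2c(c1)C=C(CC1CN=CN1)CC2`: in this assay compound 2 gives 50.1 nM.
Compound 3, `C1=NCC(Cc2cc3ccccc3o2)N1`: in this assay compound 3 gives 63.1 nM.

Compound 2 differs from compound 1 by one change only, (fluoro in place of hydrogen on an aromatic carbon). The step it made was no change at the digits printed from compound 1 to compound 2 (within the scatter), so the added fluorine left the read-out essentially where it was.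

Compound 3 carries a different core; how its core differs from that of compound 1 is not broken down here. Its value sits close to those of compound 1 and compound 2, with the gaps inside the usual scatter of such measurements.

The unmeasured compound 4, `Fc1ccc2oc(CC3CN=CN3)cc2c1`, differs from compound 3 by fluoro in place of hydrogen on an aromatic carbon. The place of the new fluorine is described in the same words as for the pair of compound 1 and compound 2, so this is the same change on a second core. The step from compound 3 to compound 4 is therefore expected to be a 1.0-fold lower number from compound 3 to compound 4 (0.00 log units; within the scatter), resting on the step of no change at the digits printed from compound 1 to compound 2 (within the scatter). Compound 4 is estimated at 63 nM, with a likely range from 30 nM to 130 nM.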

Compound 4, inhibition constant: 794 nM
Compound 4: middle estimate off by 13-fold (1.10 log units), on the low side; the whole stated range lies below it.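

In this assay, fluoro in place of hydrogen on an aromatic carbon gave a 13-fold higher number from compound 3 to compound 4 (1.10 log units; beyond the scatter), so on the core of compound 3 this small change clearly weakened inhibition. Set beside the earlier pair, the step did not carry over from one core to the other: the same change on two cores in this assay, no change at the digits printed (within the scatter) from compound 1 to compound 2 and a 13-fold higher number (1.10 log units; beyond the scatter) from compound 3 to compound 4, 13-fold (1.10 log units) apart, beyond the scatter of two such steps. In this series, then, the result of adding this fluorine on one core is no safe guide to its result on another, but two pairs do not show which feature of the cores lies behind the gap or how a third core would respond.

The compounds shown leave open whether another group on the same aromatic carbon, such as chloro, methoxy or a nitrile, would follow the pattern of fluoro on each core. They also leave open whether a longer chain in place of the present link would widen or narrow the gap between the two steps.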